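Removing the Nitro Group: Compound 3 to Compound 4

The source may hold more compounds than are shown below. What is called first, only, known or untested is meant among the compounds shown, and "the series" means these compounds.

Measured compounds in a functional assay on the whole organism (strain albino) with Mus musculus as the target, in the maximal electroshock model, with a stated time of 4 h; on this read-out lower numbers stand for an effect already at smaller amounts and higher numbers for an effect only at larger amounts of compound:
- compound 1, `Cc1ccc(Nc2nnc(Nc3nc(-c4ccc(Cl)cc4)cs3)s2)cc1`, gives 100 mg/kg
- compound 2, `Cc1ccc(Nc2nnc(Nc3nc(-c4ccc(Br)cc4)cs3)s2)cc1`, gives 100 mg/kg
- compound 3, `Cc1ccc(Nc2nnc(Nc3nc(-c4ccc([N+](=O)[O-])cc4)cs3)s2)cc1`, gives 100 mg/kg

Compound 3 stands level with compounds 1 and 2 on the numbers shown. The step of no change at the digits printed from compound 1 to compound 3 (within the scatter) and the step of no change at the digits printed from compound 2 to compound 3 (within the scatter) both lie within the scatter, and so does the step of no change at the digits printed from compound 1 to compound 2 (within the scatter), so the three values cannot be told apart.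

Compound 4 is `Cc1ccc(Nc2nnc(Nc3nc(-c4ccccc4)cs3)s2)cc1`. It differs from compound 3 by hydrogen in place of nitro on an aromatic carbon. Among the compounds with values here, no measured step removes a group from this place altogether; the three measured steps each exchange one group there for another, and none of them moved the read-out beyond the scatter. Within the data shown here, they are the only guide, and they point to a change of the group at this place leaving the number where it is.

Compound 4 is therefore expected to give 100 mg/kg, with a range from 50 mg/kg to 200 mg/kg, so that the expected step is no change at the digits printed from compound 3 to compound 4 (within the scatter), none beyond the scatter.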

Compound 4, minimum effective dose: 100 mg/kg
The estimate for compound 4 equals the measured number at the digits printed; the measured number falls inside the stated range.
By their numbers in this assay, from the lowest: compounds 1, 2, 3 and 4 (each within the scatter of the next).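

Removing the nitro group altogether (no change at the digits printed from compound 3 to compound 4 (within the scatter)) in this assay shows that the read-out holds even with plain hydrogen at this place. The same holds for removing the bromo group (no change at the digits printed from compound 2 to compound 4 (within the scatter)) and the chloro group (no change at the digits printed from compound 1 to compound 4 (within the scatter)), so among these four compounds, none of the three groups is needed on this aromatic carbon to keep the number where it is. No measurement shown here explains why the read-out stays the same across these changes.

On these data alone, whether an amine, a carboxylic acid or a longer chain at this place would move the number remains open. So does the effect of changes elsewhere in the molecule, since the four compounds shown differ only at this one place.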